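From methoxy to fluoro: what to expect of compound 4

The source may hold more compounds than are shown below. What is called first, only, known or untested is meant among the compounds shown, and "the series" means these compounds.

Values in a functional assay on A549 cells (Homo sapiens) for cytotoxicity, read by MTT assay, with a stated time of 72 h; on this read-out higher numbers stand for weaker inhibition and lower numbers for stronger inhibition:
compound 1 `O=S(=O)(c1ccc(F)cc1)c1nc2ccccc2nc1N1CCCC(O)C1`: 8170 nM
compound 2 `O=S(=O)(c1ccccc1)c1nc2ccccc2nc1N1CCC(O)CC1`: 2060 nM
compound 3 `COc1ccc(S(=O)(=O)c2nc3ccccc3nc2N2CCC(O)CC2)cc1`: 5110 nM

Going by the values given here, compound 3, at 5110 nM, lies within the scatter of compound 1, and the one measured step reaching it is a 2.5-fold higher number from compound 2 to compound 3 (0.39 log units; beyond the scatter). Next comes compound 4 `O=S(=O)(c1ccc(F)cc1)c1nc2ccccc2nc1N1CCC(O)CC1`, with fluoro in place of methoxy on an aromatic carbon, para to a large group (fluoro in place of methoxy on an aromatic carbon). Among the compounds with values here, no measured step makes this exchange directly. The nearest is the step with methoxy in place of hydrogen, so losing methoxy may undo part of that rise. Compound 1, also a 4-fluorophenyl compound, gives 8170 nM, which argues against expecting much. The expected change in this assay is small, toward a lower number: a 1.5-fold lower number from compound 3 to compound 4 (0.16 log units; within the scatter). For compound 4 the estimated value is 3500 nM, with an expected range from 1600 nM to 7500 nM.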

Compound 4, half-maximal inhibitory concentration: 20200 nM
Compound 4: middle estimate off by 5.8-fold (0.76 log units), on the low side; the measured number lies above the stated range.
By their numbers in this assay, from the lowest: compound 2; then compounds 3 and 1 (each within the scatter of the next); then compound 4.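

In this assay, fluoro does not fall between hydrogen and methoxy at this position: a 4.0-fold higher number from compound 3 to compound 4 (0.60 log units; beyond the scatter), and fluoro in place of hydrogen gives a 9.8-fold higher number from compound 2 to compound 4 (0.99 log units; beyond the scatter), so of the three groups fluoro gives the highest number. The hydroxyl position on the piperidine also matters with the 4-fluorophenyl group held constant, with a 2.5-fold higher number from compound 1 to compound 4 (0.39 log units; beyond the scatter). Nothing available explains either change.

On these data alone, whether an amine or a nitrile on this aromatic carbon would bring the number back toward that of compound 2 remains open. So does whether the 3-hydroxypiperidin-1-yl to 4-hydroxypiperidin-1-yl step would run the same way with hydrogen or methoxy on the ring.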